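The compounds below may be only part of what the source reports. "The series", "measured", "known", "first", "only" and "open" are said of these compounds alone.

Measured in a functional assay on the whole organism with Mus musculus as the target; on this read-out higher numbers stand for an effect only at larger amounts of compound and lower numbers for an effect already at smaller amounts:
- Compound 1 `CCCn1c(-c2ccc(Cl)cc2)nn(C)c1=S`: > 12.5 mg/kg, a limit
- Compound 2 `Cn1nc(-c2ccc(Cl)cc2)nc1S`: > 50 mg/kg, a limit
- Compound 3 `COc1ccc(-c2nn(C)c(=S)n2C)cc1`: > 25 mg/kg, a limit

Like compound 1 and compound 2, compound 3 stands only at a limit, > 25 mg/kg. Within the data shown here, no value is an exact number, and no measured pair shows the effect of a single change.

Compound 4 `Cc1ccc(-c2nn(C)c(=S)n2C)cc1` has methyl in place of methoxy on an aromatic carbon. The expectation rests on compound 3 alone, with its limit of > 25 mg/kg. An expected step that the limit leaves unreadable from compound 3 to compound 4 in this assay would stay within the scatter, with no clear direction, and another limit is quite possible. For compound 4 the estimate is 30 mg/kg, with an expected range of 10 mg/kg to 90 mg/kg.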

Compound 4, dose for half-maximal effect: 1.74 mg/kg
Compound 4: the middle estimate sits 17-fold (1.24 log units) above what was measured; measured number below the stated range.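

In this assay, methyl in place of methoxy on an aromatic carbon gives an at least 14-fold lower number from compound 3 to compound 4 (1.15 log units; beyond the scatter), so this position responds strongly to a small change, and compound 4 gives the series its first exact value. Compound 3 stands only at a limit, so the full size of the step stays open: the limit of > 25 mg/kg in this assay, at which 1 of the 4 values shown sits.

The compounds shown leave open whether a longer chain such as ethyl, or an amine, on this aromatic carbon would keep the low number. Chlorine there appears only in compound 1 and compound 2, which also differ elsewhere from compound 4.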